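Moving the methyl: 4-methylphenyl to 3-methylphenyl

The compounds below may be only part of what the source reports. "The series", "measured", "known", "first", "only" and "open" are said of these compounds alone.

In a functional assay on HCT-15 cells (Homo sapiens) for antiproliferative activity, read by MTT assay, with a stated time of 72 h (a lower number here means a stronger inhibitor, a higher number a weaker inhibitor), compound 1 `CCCCCn1ccnc1-c1cc(OC)c(OC)c(OC)c1` gives > 100000 nM as a limit of the assay and not a number. Within the data shown here, compound 2 `COc1cc(-c2nccn2-c2ccc(C)cc2)cc(OC)c1OC` gives 800 nM as the only true number so far. Compound 3 `COc1cc(-c2nccn2-c2cccc(C)c2)cc(OC)c1OC` has the same atoms joined differently, with 3-methylphenyl in place of 4-methylphenyl on an aromatic nitrogen is the whole change. Among the measured compounds shown here, one measured step bears on this place: an at least 120-fold lower number from compound 1 to compound 2 (2.09 log units; beyond the scatter) is large, follows 4-methylphenyl replacing pentyl and rests on the limit of > 100000 nM in this assay, at which 1 of the 2 values shown sits, as its reference. That step shows how much the group on this nitrogen can matter, but it does not test moving the methyl. A much smaller change in this assay is therefore expected, leaning towards a higher number. The expected step is a 1.9-fold higher number from compound 2 to compound 3 (0.27 log units; within the scatter) on this estimate. For compound 3 the estimated value is 1500 nM with an expected range of 400 nM to 6000 nM in this assay once tested.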

Compound 3, half-maximal inhibitory concentration: 1600 nM
Compound 3: the middle estimate sits 1.1-fold (0.03 log units) below what was measured; the measured number falls inside the stated range.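

In this assay, 3-methylphenyl in place of 4-methylphenyl on the aromatic nitrogen gives a 2.0-fold higher number from compound 2 to compound 3 (0.30 log units; within the scatter), so this assay does not separate compound 2 from compound 3. Within these two compounds, the place of the methyl on the phenyl ring has no readable effect, while a second methylphenyl group now stands apart from pentyl: an at least 62-fold lower number from compound 1 to compound 3 (1.79 log units; beyond the scatter). That step, like the one for compound 2, rests on a limit and not on a number: the limit of > 100000 nM in this assay, at which 1 of the 3 values shown sits.

Whether the methyl is needed at all remains open, as the series shown holds no plain phenyl on this nitrogen. Also open, going by these compounds, is how this position would respond to a benzyl or pyridyl group, or to an amine or carboxylic acid on the phenyl ring.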